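Removing One Methoxy Group: What Changes in Cell Growth Inhibition

The source may report more compounds than this note shows. Statements on the series, on what has been measured and on what is new or still open speak of the compounds shown alone.

Of the compounds shown here, three have so far been measured in a functional assay on U-251 cells (Homo sapiens) for cytotoxicity, read by sulforhodamine B assay, with a stated time of 48 h, tested at 0.01 uM; on this read-out higher numbers stand for a weaker effect at the one concentration tested and lower numbers for a stronger effect. Compound 1 `COc1cc(-c2cc(/C=C/C(=O)c3ccc(N)cc3)[nH]n2)cc(OC)c1OC` gives 98%, compound 2 `COc1ccc(-c2cc(/C=C/C(=O)c3ccc(N)cc3)[nH]n2)cc1OC` gives 95%, and compound 3 `COc1cc(C(=O)/C=C/c2cc(-c3cc(OC)c(OC)c(OC)c3)n[nH]2)cc(OC)c1OC` gives 96%. All three numbers sit close together, and the gaps between them lie within the usual scatter of repeated measurements, so none of the three can be set apart from the others on this read-out.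

Compound 2 differs from compound 1 in one place only: hydrogen in place of methoxy on an aromatic carbon. This change gave a number 3 percentage points lower from compound 1 to compound 2 (within the scatter). Compound 4 `COc1ccc(-c2cc(/C=C/C(=O)c3cc(OC)c(OC)c(OC)c3)[nH]n2)cc1OC` has not yet been measured. It differs from compound 3 by the same change, (hydrogen in place of methoxy on an aromatic carbon), made at a place described in the same words. The difference between the core of compound 1 and the core of compound 3 is not broken down here.

In this assay the step from compound 3 to compound 4 is expected to be a number 2 percentage points lower from compound 3 to compound 4 (within the scatter), about the size of the earlier step, because the same change gave a number 3 percentage points lower from compound 1 to compound 2 (within the scatter). Compound 4 is therefore estimated at 94%, with the number expected to fall between 86% and 100%.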

Compound 4, a percentage reported as activity, at one concentration (the size of the read-out at that concentration, not a potency): 99%
Estimate against measurement, compound 4: 5 percentage points below; the range from low to high includes it.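

Replacing methoxy with hydrogen on an aromatic carbon of compound 3 gave, in this assay, a number 3 percentage points higher from compound 3 to compound 4 (within the scatter). Set beside the earlier step, the result on the second core does not differ from the first: the same change on two cores in this assay, a number 3 percentage points lower (within the scatter) from compound 1 to compound 2 and a number 3 percentage points higher (within the scatter) from compound 3 to compound 4, 6 percentage points apart, within the scatter of two such steps This shows that the change left the read-out within the usual scatter on both cores, but neither step is large enough to show a real effect, so the pair does not show that an effect of this change would carry from one core to another, and a single concentration says nothing about potency.

The compounds shown carry only methoxy or hydrogen at the changed place, so it remains open how a hydroxyl group, a chlorine atom or a longer chain such as ethoxy would read there. On these data alone, it also remains open whether any group on an aromatic carbon of these cores can move the read-out beyond the scatter.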